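Adding a Sugar to Compound 2: Expected Cytotoxicity

A few compounds are considered here, and "the series" means these few. Any claim that something is new, unique, unknown or untested is made for them only; others in the source may bear on it.

The compounds measured so far, with their values:
compound 1, `CCCCC#Cc1c[nH]c(=O)[nH]c1=O`: 113000 nM
compound 2, `O=c1[nH]cc(C#CC(O)c2ccccc2)c(=O)[nH]1`: 38400 nM
compound 3, `O=c1[nH]cc(C#CC2CC2)c(=O)[nH]1`: 101000 nM

All three were tested in an ADME assay on MRC5 cells (Homo sapiens) for cytotoxicity, read by MTT assay; on this read-out higher numbers stand for lower toxicity in this test and lower numbers for higher toxicity in this test. Among the three numbers, compound 2 gives the lowest one, which on this read-out means the highest toxicity in this test; its gaps to compound 3, the nearest, and to compound 1, the furthest, both lie beyond the scatter. For the measured compounds named here, only one pair of measured compounds differs in a single place: a 1.1-fold lower number from compound 1 to compound 3 (0.05 log units; within the scatter), a swap on the triple-bonded carbon that left the number essentially unchanged.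

Compound 4, `O=c1[nH]c(=O)n([C@@H]2O[C@H](CO)[C@@H](O)[C@H]2O)cc1C#CC(O)c1ccccc1`, differs from compound 2 in a different way: 3,4-dihydroxy-5-(hydroxymethyl)oxolan-2-yl in place of hydrogen on an aromatic nitrogen. Going by the values given here, none of the measured steps touches the aromatic nitrogen of the shared core, so the measured data offer no direct guide for this change; the one step that exists, on the triple-bonded carbon, was within the scatter. Compound 4 is therefore expected to give about 50000 nM in this assay, with a likely range from 15000 nM to 160000 nM. Among the compounds with values here, the estimated step of a 1.3-fold higher number from compound 2 to compound 4 (0.11 log units; within the scatter) is expected to stay within the scatter, while the width of the range reflects that no measured step supports it.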

Compound 4, half-maximal cytotoxic concentration: 900 nM
Compound 4: middle estimate off by 56-fold (1.74 log units), on the high side; measured number outside the range, below it.
By their numbers in this assay, from the lowest: compound 4; then compound 2; then compounds 3 and 1 (each within the scatter of the next).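

In this assay, 3,4-dihydroxy-5-(hydroxymethyl)oxolan-2-yl in place of hydrogen on an aromatic nitrogen gives a 43-fold lower number from compound 2 to compound 4 (1.63 log units; beyond the scatter), which on this read-out means higher toxicity in this test. For the compounds shown here, the only earlier single-place change, on the triple-bonded carbon, gave a 1.1-fold lower number from compound 1 to compound 3 (0.05 log units; within the scatter), so the earlier compounds showed no change in the number; this result shows that the aromatic nitrogen of the shared core is a place where one substitution can move the number far beyond the scatter. Nothing available here bears on what lies behind this large step.

On these data alone, it remains open whether a small group such as methyl, a longer chain such as hexyl, or a plain five-membered non-aromatic ring without the hydroxyl groups would move the number as far from the same nitrogen. As far as these compounds go, it is also open whether 3,4-dihydroxy-5-(hydroxymethyl)oxolan-2-yl on the same nitrogen of compound 1 or compound 3 would give a step of similar size, since for now the effect rests on a single pair.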